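Compound 4 Against the Phenethyl Amide, Compound 3

The source may hold more compounds than are shown below. What is called first, only, known or untested is meant among the compounds shown, and "the series" means these compounds.

Measured in a functional assay on HepG2 cells (Homo sapiens) for cytotoxicity, read by MTT assay, with a stated time of 48 h (on this read-out higher numbers stand for weaker inhibition and lower numbers for stronger inhibition), so far:
- Compound 1 `CC1=NN(C(=O)c2ccc(C)cc2)C(c2cc(Br)ccc2O)C1` gives 23200 nM
- Compound 2 `CCC(=O)N1N=C(C)CC1c1cc(Br)cc(Br)c1O` gives 41400 nM
- Compound 3 `CC1=NN(C(=O)CCc2ccccc2)C(c2cc(Br)cc(Br)c2O)C1` gives 9170 nM

Compound 3 stands lowest of these three in this assay, and the numbers of compound 1 and compound 2 both lie above it by more than the usual scatter. The next structure, compound 4 `CC1=NN(C(=O)c2ccc(C)cc2)C(c2cc(Br)cc(Br)c2O)C1`, puts 4-methylphenyl in place of phenethyl on a carbonyl carbon.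

Among the measured compounds shown here, only one measured step bears directly on this change. It is a 4.5-fold lower number from compound 2 to compound 3 (0.65 log units; beyond the scatter), with phenyl in place of hydrogen on a saturated chain carbon, two bonds along the chain from a carbonyl carbon. That step was modest, and compound 4 still carries one six-membered aromatic ring of carbon only, so no return to the high number of compound 2 is expected. Compound 1 carries the same 4-methylphenyl on its carbonyl carbon and reads 23200 nM in this assay, but the rest of its structure is not identical, so it offers only a loose guide. The estimated step is a 1.4-fold higher number from compound 3 to compound 4 (0.15 log units; within the scatter), an expected small rise. For compound 4 the expected value is 13000 nM, with an estimated range from 6000 nM to 28000 nM in this assay as the likely span.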

Compound 4, half-maximal inhibitory concentration: "not active" (no number reported)
The entry for compound 4 holds no number; the estimate stays without a comparison.
By their numbers in this assay, from the lowest: compound 3; then compounds 1 and 2 (each within the scatter of the next).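

In this assay, among the compounds shown here, compound 4 is recorded as "not active" with no number reported, so no step from compound 3 to compound 4 can be read. No measured evidence shown here bears on this entry. The compounds shown leave open how far the number for compound 4 would lie from that of compound 3.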